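Swapping the dihalophenyl pattern on the hydrazone arm

The source may report more compounds than this note shows. Statements on the series, on what has been measured and on what is new or still open speak of the compounds shown alone.

For the measured compounds named here, compound 3 `Cn1c(=O)c(=O)n(C2CCCC2)c2nc(N/N=C/c3cccc(Cl)c3Cl)ncc21` is the only member of this small set with a measured number: in a functional assay on A549 cells (Homo sapiens) for antiproliferative activity, read by MTT assay (on this read-out higher numbers stand for weaker inhibition and lower numbers for stronger inhibition), compound 3 gives 39100 nM. Compound 1 `Cn1c(=O)c(=O)n(C2CCCC2)c2nc(N/N=C/c3ccccc3)ncc21` gives > 100000 nM, which is a limit of this assay. Compound 2 `Cn1c(=O)c(=O)n(C2CCCC2)c2nc(N/N=C/c3ccc(O)cc3)ncc21` likewise gives > 100000 nM, again a limit. The steps of an at least 2.5-fold lower number from compound 1 to compound 3 (0.40 log units; beyond the scatter) and an at least 2.5-fold lower number from compound 2 to compound 3 (0.40 log units; beyond the scatter) both point to the dihalophenyl as the more potent arm. Compound 4 `Cn1c(=O)c(=O)n(C2CCCC2)c2nc(N/N=C/c3ccc(F)cc3Br)ncc21` keeps a dihalophenyl but rearranges it: 2-bromo-4-fluorophenyl in place of 2,3-dichlorophenyl on a carbon with a double bond to nitrogen. Going by the values given here, no measured step compares two dihalophenyls, so the change is expected to stay within the scatter, a 1.0-fold higher number from compound 3 to compound 4 (0.01 log units; within the scatter). Compound 4 is therefore estimated at 40000 nM, within 15000 nM to 110000 nM.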

Compound 4, half-maximal inhibitory concentration: 6590 nM
Beside the measured number, compound 4's estimate is 6.1-fold (0.78 log units) above it; measured number outside the range, below it.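

In this assay, for the compounds shown here, the step to 2-bromo-4-fluorophenyl gives a 5.9-fold lower number from compound 3 to compound 4 (0.77 log units; beyond the scatter) and so separates two dihalophenyl arms, which no earlier step compared. Measured against the phenyl and 4-hydroxyphenyl arms, the steps read an at least 15-fold lower number from compound 1 to compound 4 (1.18 log units; beyond the scatter) and an at least 15-fold lower number from compound 2 to compound 4 (1.18 log units; beyond the scatter) and are the largest readable here. Going by these compounds, both start from a limit of the assay, not a number, so their true size stays unknown.

On these data alone, compound 3 and compound 4 change the halogens and their placement together, so which of the two carries the drop stays open. As far as these compounds go, whether a 2-bromophenyl, a 2,4-difluorophenyl or a methoxy group on this ring would keep the number also stays open.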